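Thiosemicarbazones of a quinoline-type aldehyde: adding a methoxyphenyl

This account rests on a few compounds, and the source may have more. Where it says the series, first, only, none or still open, it means among the compounds named here.

Compound 1, `NC(=S)N/N=C/c1ccc2ccccc2n1`, is a small thiosemicarbazone in which the amide-type nitrogen carries only hydrogens. In a functional assay on SGC-7901 cells (Homo sapiens) for antiproliferative activity, read by sulforhodamine B assay, with a stated time of 72 h (on this read-out lower numbers stand for stronger inhibition and higher numbers for weaker inhibition), compound 1 gives 32700 nM. Compound 2, `S=C(N/N=C/c1ccc2ccccc2n1)Nc1ccc(Br)cc1`, carries a 4-bromophenyl on that nitrogen instead, and in this assay compound 2 gives 69400 nM. Among the compounds with values here, the only measured step is a 2.1-fold higher number from compound 1 to compound 2 (0.33 log units; beyond the scatter), a modest weakening. Compound 1 therefore stands with the lowest of the two numbers, ahead of compound 2 by a margin that exceeds the usual scatter.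

Compound 3, `COc1cccc(NC(=S)N/N=C/c2ccc3ccccc3n2)c1`, differs from compound 1 by 3-methoxyphenyl in place of hydrogen on an amide-type nitrogen. Within the data shown here, the one step that bears on it is the step from compound 1 to compound 2, where a substituted phenyl entered at the same amide-type nitrogen and the number rose by about a factor judged modest. A similar substituted phenyl entering here is expected to move the number in the same direction, upward, by a comparable and modest amount, close to the edge of the scatter.

For compound 3 the expected step is a 1.7-fold higher number from compound 1 to compound 3 (0.23 log units; within the scatter). The value of compound 3 is estimated at 55000 nM, with a range from 25000 nM to 120000 nM.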

Compound 3, half-maximal inhibitory concentration: 79400 nM
The estimate for compound 3 lay 1.4-fold (0.16 log units) below the measured number; low and high end bracket the measured number.
By their numbers in this assay, from the lowest: compound 1; then compounds 2 and 3 (each within the scatter of the next).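

In this assay, a second substituted phenyl on the amide-type nitrogen also goes with a weaker result: 3-methoxyphenyl in place of hydrogen gives a 2.4-fold higher number from compound 1 to compound 3 (0.39 log units; beyond the scatter), so the rise seen with 4-bromophenyl is not a single case. Exchanging one group for the other gives a 1.1-fold higher number from compound 2 to compound 3 (0.06 log units; within the scatter), which means that these two substituted phenyl groups cannot be told apart here, even though they carry different substituents at different ring positions. Across these three compounds, the one with only hydrogen on this nitrogen keeps the lowest number, with both substituted phenyl compounds beyond the scatter from it and neither going against this pattern. Nothing available explains why the number rises when either group enters.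

From the compounds shown here alone, whether the rise belongs to any group on this nitrogen or to phenyl rings in particular stays open, and a methyl group, a longer alkyl chain or a chain ending in an amine would test this. Unsubstituted phenyl would show whether the bromine or the methoxy group matters at all, or whether the ring alone accounts for the step.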